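The source may report more compounds than this note shows. Statements on the series, on what has been measured and on what is new or still open speak of the compounds shown alone.

Among the measured compounds shown here, in a functional assay on 786-0 cells (Homo sapiens) for inhibition, read by sulforhodamine B assay, with a stated time of 48 h, tested at 10 uM (on this read-out lower numbers stand for a stronger effect and higher numbers for a weaker effect at the one concentration tested), compound 1 `COc1cc(Cl)cc(-c2nn(-c3cccc(NC(=O)Nc4ccc(Cl)c(C(F)(F)F)c4)c3)cc2-c2ccncc2)c1` gives -4.76%, while compound 2 `COc1cc(Cl)cc(-c2nn(-c3cccc(NC(=O)Nc4cccc(C(F)(F)F)c4)c3)cc2-c2ccncc2)c1` gives 13.2%, the highest of the two numbers; the single measured step, a number 18 percentage points higher from compound 1 to compound 2 (beyond the scatter), separates them. Compound 3 `COc1cc(Cl)cc(-c2nn(-c3cccc(NC(=O)c4cccc(C(F)(F)F)c4)c3)cc2-c2ccncc2)c1` differs from compound 2 by 3-(trifluoromethyl)phenyl in place of (3-(trifluoromethyl)phenyl)amino on a carbonyl carbon. For the measured compounds named here, no measured step concerns a change at the carbonyl carbon, so nothing measured bears directly on this change, and the expectation rests on compound 2 alone. Compound 3 is therefore expected to give about 20%, most likely between 0% and 45%, which would mean an estimated a number 6.8 percentage points higher from compound 2 to compound 3 (within the scatter) that may not exceed the scatter.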

Compound 3, a percentage reported as activity, at one concentration (the size of the read-out at that concentration, not a potency): 66.6%
Compound 3: the middle estimate sits 46.6 percentage points below what was measured; the measured number lies above the stated range.
By their numbers in this assay, from the lowest: compound 1; then compound 2; then compound 3.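

In this assay, the amino nitrogen linking the carbonyl carbon to the aryl ring proves far from neutral: exchanging (3-(trifluoromethyl)phenyl)amino for 3-(trifluoromethyl)phenyl gives a number 53.4 percentage points higher from compound 2 to compound 3 (beyond the scatter) and removes one hydrogen-bond donor. Measured against the chloro-bearing partner, the change gives a number 71.4 percentage points higher from compound 1 to compound 3 (beyond the scatter) and also drops that chloro. No available evidence explains this loss.

Still open, on these data alone, is whether the amide hydrogen itself matters or the link's length does, which an oxygen or methylene at that place could separate. As far as these compounds go, whether chloro would act the same way on the 3-(trifluoromethyl)phenyl amide also remains unknown.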